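The compounds below may be only part of what the source reports. "The series", "measured", "known", "first", "only" and "open" are said of these compounds alone.

Two compounds have been measured so far in a functional assay on LOX IMVI cells (Homo sapiens) for cytotoxicity, read by MTT assay, with a stated time of 24 h; on this read-out higher numbers stand for weaker inhibition and lower numbers for stronger inhibition:

compound 1 `O=S(=O)(NCCCNc1nccc(-c2[nH]c(-c3ccccc3)nc2-c2ccc(F)c(O)c2)n1)c1ccc(Br)cc1`: 5660 nM
compound 2 `O=S(=O)(NCCCNc1nccc(-c2[nH]c(-c3ccccc3)nc2-c2ccc(Cl)c(O)c2)n1)c1ccccc1`: 2630 nM

Of these two numbers, compound 2 holds the lower one at 2630 nM, and the gap up to compound 1 lies beyond the usual scatter of such measurements. The next compound to be tested, compound 3 `O=S(=O)(NCCCNc1nccc(-c2[nH]c(-c3ccccc3)nc2-c2ccc(Cl)c(O)c2)n1)c1ccc(Br)cc1`, departs from compound 2 in one place: bromo in place of hydrogen on an aromatic carbon. Put another way, phenylsulfonyl becomes (4-bromophenyl)sulfonyl. Within the data shown here, no measured pair shows this change on its own, so the evidence is thin. Among the measured compounds shown here, the only hint comes from compound 1, which also carries the (4-bromophenyl)sulfonyl group and gives 5660 nM. That points towards a modest rise in the number, meaning somewhat weaker inhibition, though perhaps none beyond the scatter. The estimated change is a 1.4-fold higher number from compound 2 to compound 3 (0.16 log units; within the scatter). For compound 3 the expected value is 3800 nM, with an estimated range of 1800 nM to 7500 nM.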

Compound 3, half-maximal inhibitory concentration: 15500 nM
For compound 3 the middle estimate is 4.1-fold (0.61 log units) below the measured one; measured number outside the range, above it.
By their numbers in this assay, from the lowest: compound 2; then compound 1; then compound 3.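

In this assay, among these compounds, the step of a 5.9-fold higher number from compound 2 to compound 3 (0.77 log units; beyond the scatter) gives the first direct reading of bromo in place of hydrogen on the phenylsulfonyl group, and it shows that this single change weakens inhibition by more than the scatter. The step of a 2.7-fold higher number from compound 1 to compound 3 (0.44 log units; beyond the scatter) adds a second reading with the (4-bromophenyl)sulfonyl group held constant: chloro in place of fluoro on an aromatic carbon also moves the number up beyond the scatter, leaving compound 3 as the weakest of the three. No measurement is available that bears on why either change has this result.

The compounds shown leave open whether the rise that comes with bromo would also appear with fluoro in place of chloro, since the two changes are each seen only once and in a single setting. They also leave open whether this rise is particular to bromo or would follow from other groups at the same carbon of the phenyl ring, such as methoxy, an amine or a carboxylic acid.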